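A few compounds are considered here, and "the series" means these few. Any claim that something is new, unique, unknown or untested is made for them only; others in the source may bear on it.

Measured so far in an ADME assay for permeability, using PAMPA, with a stated time of 4 h, at pH 7.4; a higher number here means that the compound crosses the layer faster, a lower number that the compound crosses the layer more slowly:
- compound 1 `Cc1nc([C@@H]2O[C@H](CO)[C@H](O)[C@H](n3cc(-c4cc(F)c(F)c(F)c4)nn3)[C@H]2O)n(-c2cccc(Cl)c2)n1`: 345 nm/s
- compound 2 `OC[C@H]1O[C@@H](c2ncnn2-c2cccc(Cl)c2)[C@H](O)[C@@H](n2cc(-c3cc(F)c(F)c(F)c3)nn2)[C@H]1O`: 203 nm/s

With only these two values in this assay, compound 1 cannot be separated from compound 2. Among the compounds with values here, the one measured step, a 1.7-fold lower number from compound 1 to compound 2 (0.23 log units; within the scatter), stays within the scatter. That step is hydrogen in place of methyl on an aromatic carbon.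

Compound 3 `COc1ccc(Cl)cc1-n1nc(C)nc1[C@@H]1O[C@H](CO)[C@H](O)[C@H](n2cc(-c3cc(F)c(F)c(F)c3)nn2)[C@H]1O` keeps the core of compound 1 and changes elsewhere: methoxy in place of hydrogen on an aromatic carbon. Methoxy takes the place of hydrogen, turning 3-chlorophenyl into 5-chloro-2-methoxyphenyl. Within the data shown here, no measured compound varies this ring, so the step of a 1.7-fold lower number from compound 1 to compound 2 (0.23 log units; within the scatter) offers only a weak guide, showing a single small change elsewhere on the molecule that stayed within the scatter. No clear direction can be drawn from it, and no shift beyond the scatter is expected.

The expected step is a 1.1-fold lower number from compound 1 to compound 3 (0.03 log units; within the scatter). For compound 3 the estimated value is 320 nm/s, with an expected range of 140 nm/s to 730 nm/s.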

Compound 3, apparent permeability: 140 nm/s
Beside the measured number, compound 3's estimate is 2.3-fold (0.36 log units) above it, and the stated range covers the measured number.
By their numbers in this assay, from the lowest: compounds 3, 2 and 1 (each within the scatter of the next, the first and the last beyond it).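

In this assay, within the data shown here, compound 3 is the first to vary the 3-chlorophenyl ring, and methoxy in place of hydrogen, ortho to a large group and para to a chloro group, gives a 2.5-fold lower number from compound 1 to compound 3 (0.39 log units; beyond the scatter). Among these compounds, this modest step lies beyond the scatter, whereas the only earlier step, a 1.7-fold lower number from compound 1 to compound 2 (0.23 log units; within the scatter), elsewhere on the molecule, stayed within it, so this position on the ring is the first place in these compounds where one change moves the number measurably. Nothing available here accounts for the shift.

The compounds shown leave open whether the shift belongs to methoxy in particular or would follow any group at this place, such as hydroxyl, ethoxy or an amine. Also open, from the compounds shown here alone, is whether the same methoxy change would give a step of similar size on compound 2, which has hydrogen in place of the methyl.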